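Amide nitrogen exchange in a small series

A few compounds are considered here, and "the series" means these few. Any claim that something is new, unique, unknown or untested is made for them only; others in the source may bear on it.

Measured so far in an in vitro ADME assay on microsomes from liver (Mus musculus) for pharmacokinetics, read by LC-MS, with a stated time of 10 min, tested at 1 uM; on this read-out higher numbers stand for fast clearance and lower numbers for slow clearance:
- compound 1 `CN1C[C@H](C(=O)Nc2cccc(F)c2)[C@@H](c2ccc(/C=C/C(=O)Nc3ccccc3N)cc2)C1`: 56 mL/min/kg
- compound 2 `CN1C[C@H](C(=O)Nc2ccc(Cl)cc2F)[C@@H](c2ccc(/C=C/C(=O)Nc3ccccc3N)cc2)C1`: 43 mL/min/kg

Compound 2 stands within the scatter of compound 1, and the series offers only these two numbers. Not yet measured is compound 3 `CC(C)NC(=O)[C@H]1CN(C)C[C@@H]1c1ccc(/C=C/C(=O)Nc2ccccc2N)cc1`. The structural change from compound 2 is isopropyl in place of 4-chloro-2-fluorophenyl on an amide-type nitrogen.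

Among the compounds with values here, one measured step bears on this, made at the same kind of nitrogen: a 1.3-fold lower number from compound 1 to compound 2 (0.11 log units; within the scatter), which lies within the scatter. That step is a weak guide, since an aromatic ring stays on the nitrogen there. Within the data shown here, in compound 3 the ring leaves and no ring enters, and no measured compound carries isopropyl. The data therefore give no direction, and no step beyond the scatter is expected in this assay, though the uncertainty is wide. The expected change is a 1.0-fold lower number from compound 2 to compound 3 (0.01 log units; within the scatter). For compound 3 the estimated clearance is 42 mL/min/kg, with an expected range of 20 mL/min/kg to 85 mL/min/kg.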

Compound 3, clearance: 12 mL/min/kg
Estimate against measurement, compound 3: 3.5-fold (0.54 log units) above; measured number below the stated range.
By their numbers in this assay, from the lowest: compound 3; then compounds 2 and 1 (each within the scatter of the next).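

In this assay, the amide-type nitrogen proves responsive to the kind of group it carries: isopropyl in place of 4-chloro-2-fluorophenyl gives a 3.6-fold lower number from compound 2 to compound 3 (0.55 log units; beyond the scatter), and isopropyl in place of 3-fluorophenyl gives a 4.7-fold lower number from compound 1 to compound 3 (0.67 log units; beyond the scatter). Within the data shown here, exchanging one substituted phenyl for another gave only a 1.3-fold lower number from compound 1 to compound 2 (0.11 log units; within the scatter), so the first step beyond the scatter at this position comes with the change from an aromatic ring to a group with no ring and fewer heavy atoms. Nothing in the data identifies what underlies this shift, and the loss of the ring cannot be separated from the change in size.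

Open, going by these compounds, is whether methyl, tert-butyl, cyclohexyl or a longer alkyl chain would stay close to compound 3 in this assay, and whether a chain ending in a hydroxyl group or an amine would do the same. On these data alone, all three compounds share one core, so it also remains open whether the step from an aromatic group to isopropyl carries over to a changed core.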